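A few compounds are considered here, and "the series" means these few. Any claim that something is new, unique, unknown or untested is made for them only; others in the source may bear on it.

Compound 1 `C=CC(=O)Nc1cccc(Oc2nc(Nc3cccc(OC)c3)nc3ccsc23)c1` is the stronger of the two compounds measured in a functional assay on MCF7 cells (Homo sapiens) for inhibition, read by MTT assay, with a stated time of 72 h (a lower number here means a stronger inhibitor, a higher number a weaker inhibitor), where compound 1 gives 19000 nM. For the measured compounds named here, its nearest neighbour is compound 2 `COc1cccc(Nc2nc(Oc3cccc(NC(=O)/C=C/C(C)C)c3)c3sccc3n2)c1`, which in this assay gives 43900 nM; the step of a 2.3-fold higher number from compound 1 to compound 2 (0.36 log units; beyond the scatter) is the only measured change on this part of the molecule. Compound 3 `CCC/C=C/C(=O)Nc1cccc(Oc2nc(Nc3cccc(OC)c3)nc3ccsc23)c1` differs from compound 1 by pent-1-en-1-yl in place of vinyl on a carbonyl carbon. Going by the values given here, this change resembles the one from compound 1 to compound 2, in that a longer unsaturated chain replaces the vinyl group on the carbonyl carbon of the amide, so the step to compound 3 is expected to lie in the same direction and of similar size, a weakening beyond the usual scatter, a 2.1-fold higher number from compound 1 to compound 3 (0.32 log units; beyond the scatter). Compound 3 is therefore estimated to give about 40000 nM in this assay, within a range of 15000 nM to 110000 nM.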

Compound 3, half-maximal inhibitory concentration: 5020 nM
Compound 3: middle estimate off by 8.0-fold (0.90 log units), on the high side, and the stated range ends above it.
By their numbers in this assay, from the lowest: compound 3; then compound 1; then compound 2.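

In this assay, the position on the carbonyl carbon turns out to respond in both directions: a 3.8-fold lower number from compound 1 to compound 3 (0.58 log units; beyond the scatter) runs opposite to a 2.3-fold higher number from compound 1 to compound 2 (0.36 log units; beyond the scatter), so replacing vinyl with a longer unsaturated chain does not by itself set the direction of the change. The two longer chains differ only in propyl for isopropyl on the double-bonded chain carbon, and that single change gives an 8.7-fold lower number from compound 2 to compound 3 (0.94 log units; beyond the scatter), the largest step among the three compounds. Nothing available here explains why these two chains part so widely.

The compounds shown leave open whether a longer chain than pent-1-en-1-yl would lower the number further. They also leave open how an amine at the end of the chain, or a saturated propyl-bearing chain in place of the double bond, would behave.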